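Removing the Benzylsulfanyl Group from Compound 2

The compounds below may be only part of what the source reports. "The series", "measured", "known", "first", "only" and "open" are said of these compounds alone.

Measured compounds:
compound 1 `Nc1ncnc2c1nc(O)n2Cc1ccc(Cl)cc1`: 10 uM
compound 2 `Nc1nc(SCc2ccccc2)nc2c1nc(O)n2Cc1ccccc1`: 0.1 uM
compound 3 `Nc1nc(S)nc2c1nc(O)n2Cc1ccccc1`: 10 uM

In a functional assay (spleen, spleen) for activation, with Mus musculus as the target (on this read-out higher numbers stand for an effect only at larger amounts of compound and lower numbers for an effect already at smaller amounts), compound 2 gives 0.1 uM, the lowest of the three numbers; compound 1 and compound 3 each stand a step beyond the scatter higher than it. Compound 4 `Nc1ncnc2c1nc(O)n2Cc1ccccc1` differs from compound 2 in one place: hydrogen in place of benzylsulfanyl on an aromatic carbon. Going by the values given here, the one measured step that bears on this change is a 100-fold higher number from compound 2 to compound 3 (2.00 log units; beyond the scatter), where the sulfur stays but the benzyl on it is gone; that step is large and beyond the scatter. In this assay compound 1 gives 10 uM and compound 3 gives 10 uM, so among the three measured compounds only compound 2, which keeps the whole benzylsulfanyl group, reaches the low number. On this basis compound 4 is expected to show a 100-fold higher number from compound 2 to compound 4 (2.00 log units; beyond the scatter), a step in the same direction as the loss of benzyl from compound 2 to compound 3. The estimate for compound 4 is 10 uM, with a range from 1 uM to 100 uM.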

Compound 4, minimum effective concentration: 10 uM
Compound 4: the middle estimate sits on the measured number at the digits printed, and the stated range covers the measured number.
By their numbers in this assay, from the lowest: compound 2; then compounds 1, 3 and 4 (each within the scatter of the next).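

Replacing the whole group in this assay gives a 100-fold higher number from compound 2 to compound 4 (2.00 log units; beyond the scatter), which places the low number of compound 2 with the benzylsulfanyl group on the aromatic carbon between two ring nitrogen atoms. At that carbon, sulfanyl and hydrogen cannot be told apart, with no change at the digits printed from compound 3 to compound 4 (within the scatter), so the sulfur alone does not recover any of the step seen with the full group. The chloro group on the benzyl ring of compound 1 likewise makes no difference in this setting, with no change at the digits printed from compound 1 to compound 4 (within the scatter) to show for it. Nothing given here explains why the benzylsulfanyl group matters. On these data alone, it remains open whether a methylsulfanyl group, with a much shorter chain on the sulfur, would keep any of the low number. Equally open, as far as these compounds go, is whether a benzylamino group, with nitrogen in place of the sulfur, would hold it at this carbon.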